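Compound 1 to compound 3: trifluoromethoxy in place of ethyl

This account rests on a few compounds, and the source may have more. Where it says the series, first, only, none or still open, it means among the compounds named here.

In an ADME assay on HCT-116 cells (Homo sapiens) for cytotoxicity, read by CellTiter-Glo, with a stated time of 72 h (a higher number here means a weaker inhibitor, a lower number a stronger inhibitor), compound 1 (`CCc1cc(Br)ccc1S(=O)(=O)N1CCC(N2CCC(C)CC2)CC1`) gives > 5000 nM as a limit of the assay and not a number. In this assay compound 2 (`CC1CCN(C2CCN(S(=O)(=O)c3cccc(N)c3)CC2)CC1`) gives > 5000 nM and this too is a limit. The measured set therefore consists of the limit of > 5000 nM in this assay, at which 2 of the 2 values shown sit, and holds no numeric value.

Compound 3 (`CC1CCN(C2CCN(S(=O)(=O)c3ccc(Br)cc3OC(F)(F)F)CC2)CC1`) keeps the core of compound 1 and carries trifluoromethoxy in place of ethyl on an aromatic carbon, ortho to a large group and meta to a bromo group (trifluoromethoxy in place of ethyl on an aromatic carbon).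

For the measured compounds named here, no step between measured compounds is available, so the data give no size for this change. In this assay no step beyond the scatter is expected, in either direction. Going by the values given here, that expectation rests only on compound 1 with its limit of > 5000 nM and on the single change in structure. An estimated step that the limit leaves unreadable from compound 1 to compound 3 is only a rough figure. For compound 3 the expected value is 6000 nM with an estimated range of 2500 nM to 15000 nM and a good chance that the assay reports only a limit.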

Compound 3, half-maximal inhibitory concentration: > 5000 nM
Compound 3: no number, only a limit (the forecaster's own chance of this, stated with the estimate: 75%); the middle value does not contradict the limit.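

In this assay compound 3 gives > 5000 nM, a limit of the assay and not a number. No step from compound 1 to compound 3 can be read, because both compounds stop at the same limit: the limit of > 5000 nM in this assay, at which 3 of the 3 values shown sit.

The compounds shown leave open how strongly any of them inhibits in this assay, and whether trifluoromethoxy in place of ethyl changes that at all.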